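Five-Membered Ring in Place of Six: An Expected Cost

The compounds below may be only part of what the source reports. "The series", "measured", "known", "first", "only" and "open" are said of these compounds alone.

Compound 1 `O=c1c(CSC(=S)N2CCCC2)coc2ccccc12`: in a functional assay on HeLa cells (Homo sapiens) for antiproliferative activity, read by MTT assay, with a stated time of 72 h (a higher number here means a weaker inhibitor, a lower number a stronger inhibitor), compound 1 reaches only a limit, > 25000 nM.
Compound 2 `O=c1c(CSC(=S)N2CCOCC2)coc2cc(Cl)ccc12`: in this assay compound 2 gives 2000 nM.
Compound 3 `O=c1c(CSC(=S)N2CCCCC2)coc2cc(Cl)ccc12`: in this assay compound 3 gives 440 nM.

Compound 3 holds the lowest of the two numbers shown. Its nearest neighbour is compound 2, and the step of a 4.5-fold lower number from compound 2 to compound 3 (0.66 log units; beyond the scatter) lies beyond the usual scatter, so compound 3 is clearly the stronger of the two. Compound 1 stands at the limit of the assay the limit of > 25000 nM in this assay, at which 1 of the 3 values shown sits, and therefore yields no number.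

Compound 4 `O=c1c(CSC(=S)N2CCCC2)coc2cc(Cl)ccc12` has not yet been measured. It differs from compound 3 in one place: pyrrolidin-1-yl in place of piperidin-1-yl on a thiocarbonyl carbon. Within the data shown here, only one measured step touches the ring on the thiocarbonyl carbon, a 4.5-fold lower number from compound 2 to compound 3 (0.66 log units; beyond the scatter), and it shows that this position matters, with a modest but real change from one six-membered ring to another. Compound 1 carries the same pyrrolidin-1-yl ring as compound 4 but lacks the chlorine of compound 3, and in this assay compound 1 reaches only the limit. Among the measured compounds shown here, no measured pair isolates the chlorine, so its weight is unknown.

On this basis the smaller ring is expected to weaken the inhibitor, with an estimated step of a 3.4-fold higher number from compound 3 to compound 4 (0.53 log units; beyond the scatter). Compound 4 is expected to give 1500 nM, within a range from 400 nM to 8000 nM.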

Compound 4, half-maximal inhibitory concentration: 1300 nM
For compound 4 the middle estimate is 1.2-fold (0.06 log units) above the measured one, within the range that was stated.
By their numbers in this assay, from the lowest: compound 3; then compounds 4 and 2 (each within the scatter of the next). At a limit, above all of these: compound 1.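

In this assay, the ring on the thiocarbonyl carbon now has a second measured step, and this one changes ring size: a 3.0-fold higher number from compound 3 to compound 4 (0.47 log units; beyond the scatter). Placing the morpholin-4-yl and pyrrolidin-1-yl rings side by side gives a 1.5-fold lower number from compound 2 to compound 4 (0.19 log units; within the scatter), so these two rings cannot be ordered, and among the three chlorine-bearing compounds only the piperidin-1-yl ring of compound 3 stands clearly apart. The chlorine, whose weight could not be judged before, now has a pair of its own, an at least 19-fold lower number from compound 1 to compound 4 (1.28 log units; beyond the scatter), a large step whose true size stays open, since one end of it is a limit and not a number: the limit of > 25000 nM in this assay, at which 1 of the 4 values shown sits.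

The compounds shown do not tell whether a seven-membered azepan-1-yl ring or an open-chain diethylamino group on the thiocarbonyl carbon would go beyond the piperidin-1-yl ring or fall short of it. They also leave open whether fluoro or bromo could stand in place of chloro, and how large the chlorine step would be with a piperidin-1-yl ring in place of the pyrrolidin-1-yl ring.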